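From methoxy to fluoro: what to expect of compound 4

A few compounds are considered here, and "the series" means these few. Any claim that something is new, unique, unknown or untested is made for them only; others in the source may bear on it.

In a functional assay on HepG2 cells (Homo sapiens) for antiproliferative activity, read by MTT assay, with a stated time of 72 h (on this read-out lower numbers stand for stronger inhibition and higher numbers for weaker inhibition), the measured compounds read as follows:
- Compound 1 (`CC(C)N1C(=O)COc2ccc(-c3cccc(NS(=O)(=O)c4ccc(F)cc4)c3)cc21`) gives > 40000 nM as a limit of the assay
- Compound 2 (`O=C1COc2ccc(-c3cccc(NS(=O)(=O)c4ccc(F)cc4)c3)cc2N1c1ccc(Cl)cc1`) gives 27800 nM
- Compound 3 (`COc1ccc(N2C(=O)COc3ccc(-c4cccc(NS(=O)(=O)c5ccc(F)cc5)c4)cc32)cc1`) gives 29800 nM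

Only compound 2 and compound 3 carry actual numbers, and the two cannot be told apart, since the step between them is a 1.1-fold higher number from compound 2 to compound 3 (0.03 log units; within the scatter) and nothing more. Compound 3 therefore stands level with compound 2 within the scatter, in the weak region of this assay near the limit reached by compound 1.

Compound 4 (`O=C1COc2ccc(-c3cccc(NS(=O)(=O)c4ccc(F)cc4)c3)cc2N1c1ccc(F)cc1`) differs from compound 3 in one place (fluoro in place of methoxy on an aromatic carbon) with fluoro in place of methoxy on an aromatic carbon, para to a large group. Among the measured compounds shown here, no measured compound has 4-fluorophenyl there. The closest guide is the exchange of chloro and methoxy at the same carbon, which gave a 1.1-fold higher number from compound 2 to compound 3 (0.03 log units; within the scatter) in this series. For the measured compounds named here, replacing isopropyl gave an at least 1.4-fold lower number from compound 1 to compound 2 (0.15 log units; that floor lies within the scatter) and also an at least 1.3-fold lower number from compound 1 to compound 3 (0.12 log units; that floor lies within the scatter) as the only other evidence. With these steps as a guide, no change beyond the scatter is expected. The expected step is a 1.1-fold lower number from compound 3 to compound 4 (0.04 log units; within the scatter) in this estimate. Compound 4 is therefore expected near 27000 nM with an estimated range of 14000 nM to 40000 nM in this assay once it is measured.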

Compound 4, half-maximal inhibitory concentration: > 40000 nM
Compound 4: no number, only a limit; the forecaster's own chance of this, stated with the estimate: 15%; middle value at least 1.4-fold (0.17 log units) away from the limit.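

In this assay compound 4 gives > 40000 nM, which is a limit of the assay and not a number. The two readable steps, an at least 1.3-fold higher number from compound 3 to compound 4 (0.12 log units; that floor lies within the scatter) and an at least 1.4-fold higher number from compound 2 to compound 4 (0.15 log units; that floor lies within the scatter), are only floors, so the 4-fluorophenyl group cannot yet be told apart from the 4-methoxyphenyl group or from the 4-chlorophenyl group, though the true gaps could be larger. What is new is that an aromatic ring on this nitrogen does not guarantee a readable number, as compound 4 ends at the same limit as the isopropyl compound 1, so the step between those two cannot be read, and the limit is now shared: the limit of > 40000 nM in this assay, at which 2 of the 4 values shown sit.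

The compounds shown leave open how far past the limit compound 4 lies, and so whether fluoro in place of methoxy on this aromatic carbon has any real size at all. They also leave open whether a different group at this carbon, such as an amine, a hydroxyl or a carboxylic acid, would bring a number clearly stronger than those of compound 2 and compound 3.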